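A few compounds are considered here, and "the series" means these few. Any claim that something is new, unique, unknown or untested is made for them only; others in the source may bear on it.

Measured compounds:
compound 1 `Cc1ccsc1-c1ccccc1NCC1=NCCN1` — 0.851 nM
compound 2 `Cc1cccnc1-c1ccccc1NCC1=NCCN1` — 24.6 nM

In a functional assay for activation of Alpha-1A adrenergic receptor (Homo sapiens), read by calcium flux (on this read-out higher numbers stand for an effect only at larger amounts of compound and lower numbers for an effect already at smaller amounts), compound 1 gives 0.851 nM, the lowest of the two numbers. Compound 2 gives 24.6 nM, a gap beyond the usual scatter. Compound 3 `CO/N=C/c1ccccc1NCC1=NCCN1` is unmeasured and differs from compound 1 in one place: a group of 4 heavy atoms (2 carbon, 1 nitrogen, 1 oxygen; no ring) in place of a group of 6 heavy atoms (5 carbon, 1 sulfur; one five-membered aromatic ring with 1 hetero atom), on an aromatic carbon. For the measured compounds named here, no measured pair shows a step of this kind, so the expectation rests on compound 1 alone and on the size of the change. The step of a 59-fold higher number from compound 1 to compound 3 (1.77 log units; beyond the scatter) is expected to run towards a higher number, beyond the scatter. Compound 3 is therefore estimated at 50 nM, with a range from 8 nM to 300 nM.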

Compound 3, half-maximal effective concentration: 51.3 nM
Compound 3: the middle estimate sits 1.0-fold (0.01 log units) below what was measured; the range from low to high includes it.
By their numbers in this assay, from the lowest: compound 1; then compound 2; then compound 3.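

In this assay, replacing the 3-methylthiophen-2-yl group on this aromatic carbon with an open group that has no ring gives a 60-fold higher number from compound 1 to compound 3 (1.78 log units; beyond the scatter). Compound 3 still gives a measurable effect, so a five-membered aromatic ring at this position is not required for activity, but this particular replacement costs much of the potency of compound 1. Nothing available explains the size of this step. The compounds shown leave open whether a plain phenyl ring or a small amine at this position would restore the low number of compound 1.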